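The compounds below may be only part of what the source reports. "The series", "measured", "known", "first", "only" and "open" are said of these compounds alone.

Compound 1 `S=C(Nc1ccccc1)N1N=C(c2ccc(Cl)cc2)CC1c1ccc2c(c1)OCCO2` is examined in a functional assay on WM 266-4 cells (Homo sapiens) for antiproliferative activity, read by MTT assay, with a stated time of 48 h; on this read-out lower numbers stand for stronger inhibition of growth and higher numbers for weaker inhibition of growth. In this assay compound 1 gives only a limit of the assay, > 200000 nM. Compound 2 `S=C(Nc1ccccc1)N1N=C(c2cccc(Cl)c2)CC1c1ccc2c(c1)OCCO2` carries 3-chlorophenyl in place of 4-chlorophenyl on the carbon with a double bond to nitrogen, and in this assay compound 2 likewise gives only a limit, > 200000 nM. The step that the two limits leave unreadable from compound 1 to compound 2 can thus not be read. Compound 3 `Cc1ccc(C2=NN(C(=S)Nc3ccccc3)C(c3ccc4c(c3)OCCO4)C2)cc1C`, with 3,4-dimethylphenyl on that carbon, gives 70500 nM in this assay, so that an at least 2.8-fold lower number from compound 1 to compound 3 (0.45 log units; beyond the scatter) and an at least 2.8-fold lower number from compound 2 to compound 3 (0.45 log units; beyond the scatter) are at least modest improvements. Compound 1 thus stands at the limit of > 200000 nM in this assay, at which 2 of the 3 values shown sit.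

Compound 4 `S=C(Nc1ccccc1)N1N=C(c2ccc(OCc3ccccc3)cc2)CC1c1ccc2c(c1)OCCO2` differs from compound 1 by benzyloxy in place of chloro on an aromatic carbon. Within the data shown here, no measured step involves benzyloxy; the steps to compound 3 show only that a change on this aryl ring can lower the number at least modestly. Compound 4 is therefore expected to give about 150000 nM in this assay, between 40000 nM and 400000 nM, an expected step of an at least 1.3-fold lower number from compound 1 to compound 4 (0.12 log units; that floor lies within the scatter) that is small at best, with a fair chance that only a limit is reported again.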

Compound 4, concentration for 50% growth inhibition: 420 nM
Beside the measured number, compound 4's estimate is 360-fold (2.55 log units) above it; the measured number lies below the stated range.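

Among these compounds, the earlier steps showed only that a change on this aryl ring could lower the number at least modestly. Benzyloxy in place of chloro, on the aromatic carbon para to a large group, gives an at least 470-fold lower number from compound 1 to compound 4 (2.67 log units; beyond the scatter) in this assay, so this position allows a far larger change in growth inhibition than the earlier compounds revealed. Compound 1 itself remains at a limit of the assay, not at a measured number: the limit of > 200000 nM in this assay, at which 2 of the 4 values shown sit.

The compounds shown leave open whether the oxygen or the added aromatic ring of benzyloxy carries this step, and what methoxy, which keeps the oxygen without the ring, or a longer chain such as phenethyloxy would give on this carbon. On these data alone, whether the step holds on any core other than that of compound 1 also stays open.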